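The source may report more compounds than this note shows. Statements on the series, on what has been measured and on what is new or still open speak of the compounds shown alone.

Measured in a physicochemical assay, with a stated time of 10 min; a higher number here means a weaker inhibitor, a lower number a stronger inhibitor:
- compound 1 `C/C(=N\N=C1/SCC(=O)N1Cc1cccc(F)c1)c1cccs1`: 4640000 nM
- compound 2 `C/C(=N\N=C1/SCC(=O)N1Cc1cccc(Cl)c1)c1cccs1`: 1640000 nM

For the measured compounds named here, of these two, compound 2 has the lower number, at 1640000 nM, and compound 1 is its only neighbour. The next compound is compound 3 `C/C(=N\N=C1/SCC(=O)N1Cc1cccc(Cl)c1)c1ccccn1`, which has pyridin-2-yl in place of thiophen-2-yl on a carbon with a double bond to nitrogen.

Going by the values given here, only one measured step exists, a 2.8-fold lower number from compound 1 to compound 2 (0.45 log units; beyond the scatter). It is modest and is a swap of chloro for fluoro on an aromatic carbon, so it lies at a different place from the present change. It shows the size of one change in the series but gives no direction for this one. Among the compounds with values here, no measured pair varies the group on this carbon, so the data offer no direct guide.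

The estimated change is a 1.2-fold higher number from compound 2 to compound 3 (0.09 log units; within the scatter), so no step beyond the scatter is expected in this assay, and the range is kept wide on both sides. For compound 3 the expected value is 2000000 nM, with an estimated range of 500000 nM to 8000000 nM.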

Compound 3, half-maximal inhibitory concentration: 2760000 nM
Estimate against measurement, compound 3: 1.4-fold (0.14 log units) below; low and high end bracket the measured number.
By their numbers in this assay, from the lowest: compounds 2, 3 and 1 (each within the scatter of the next, the first and the last beyond it).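

In this assay, the carbon with a double bond to nitrogen now has a measured step of its own: a 1.7-fold higher number from compound 2 to compound 3 (0.23 log units; within the scatter). With chloro held fixed, exchanging the five-membered thiophen-2-yl ring for the six-membered pyridin-2-yl ring, and so a sulfur hetero atom for a nitrogen one, gives no change that can be told from the scatter, and compound 2 and compound 3 cannot be separated at this place. Nothing available bears on why these two rings read alike.

The compounds shown leave open whether this place stays as flat with a group of a different kind, such as a cyclohexyl ring, a longer alkyl chain, a carboxylic acid or an amine, since both groups seen so far are single aromatic rings with one hetero atom. They also leave open whether the step seen on exchanging fluoro for chloro, a 2.8-fold lower number from compound 1 to compound 2 (0.45 log units; beyond the scatter), carries over when pyridin-2-yl sits on this carbon.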